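A few compounds are considered here, and "the series" means these few. Any claim that something is new, unique, unknown or untested is made for them only; others in the source may bear on it.

Compound 3 `O=C(CSc1nnc(NC(=O)CCl)s1)Nc1ccc(Br)cn1` gives 13900 nM in a functional assay on A875 cells (Homo sapiens) for antiproliferative activity, read by MTT assay, with a stated time of 48 h; a higher number here means a weaker inhibitor, a lower number a stronger inhibitor. Among the numbers shown it stands highest, with compound 2 `O=C(CSc1nnc(NC(=O)CCl)s1)Nc1ccc(Cl)cn1` nearest at 8600 nM. Compound 1 `COc1ccccc1C(=O)Nc1nnc(SCC(=O)Nc2ccc(C)cn2)s1` reaches only a limit of this assay, > 80000 nM. Compound 4 `Cc1ccc(NC(=O)CSc2nnc(NC(=O)CCl)s2)nc1` differs from compound 3 in one place: methyl in place of bromo on an aromatic carbon. For the measured compounds named here, the one measured step at this place, a 1.6-fold higher number from compound 2 to compound 3 (0.21 log units; within the scatter), stayed within the scatter, so a swap of the group here has not moved the number so far. Compound 1 also carries methyl at this place, yet its different amide prevents a one-place comparison. The expected step of a 1.1-fold higher number from compound 3 to compound 4 (0.03 log units; within the scatter) is therefore small. Compound 4 is estimated at 15000 nM, with a range from 5000 nM to 60000 nM.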

Compound 4, half-maximal inhibitory concentration: 18300 nM
For compound 4 the middle estimate is 1.2-fold (0.09 log units) below the measured one; the measured number falls inside the stated range.
By their numbers in this assay, from the lowest: compounds 2, 3 and 4 (each within the scatter of the next, the first and the last beyond it). At a limit, above all of these: compound 1.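

Methyl in place of bromo barely registers, a 1.3-fold higher number from compound 3 to compound 4 (0.12 log units; within the scatter), so at this place a carbon group fits the pattern of the two halogens. Against chloro the same group gives the first step here beyond the scatter, though only a modest one, a 2.1-fold higher number from compound 2 to compound 4 (0.33 log units; beyond the scatter). The group on the carbonyl carbon moves the number further, chloromethyl in place of 2-methoxyphenyl giving an at least 4.3-fold lower number from compound 1 to compound 4 (0.64 log units; beyond the scatter), with compound 1 at a limit of the assay: the limit of > 80000 nM in this assay, at which 1 of the 4 values shown sits.

Still open, as far as these compounds go, is how an amine or a carboxylic acid on the pyridine carbon would read. Also open, from the compounds shown here alone, is whether a longer chain on the carbonyl carbon would keep the number in this range.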